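The source may report more compounds than this note shows. Statements on the series, on what has been measured and on what is new or still open speak of the compounds shown alone.

Working notes on the series. In a functional assay on MCF7 cells (Homo sapiens) for antiproliferative activity, read by MTT assay, with a stated time of 72 h (a lower number here means a stronger inhibitor, a higher number a weaker inhibitor), compound 1 (`COc1cc2ncnc(N3CCc4ccccc43)c2cc1NC(=O)/C=C/C(C)C`) reads 6780 nM and compound 2 (`CC/C=C/C(=O)Nc1cc2c(N3CCc4ccccc43)ncnc2cc1O[C@@H]1CCOC1`) reads 8840 nM as measured. Compound 3 (`COc1cc2ncnc(N3CCCc4ccccc43)c2cc1NC(=O)C=C(C)C`) stands with them at 6870 nM on the same measure, within the scatter of both, so no order can be drawn among the three.

Among the compounds with values here, compound 4 (`CCC/C=C/C(=O)Nc1cc2c(N3CCCc4ccccc43)ncnc2cc1OC`) has no measurement yet. Relative to compound 3 the change is pent-1-en-1-yl in place of 2-methylprop-1-en-1-yl on a carbonyl carbon with pent-1-en-1-yl in place of 2-methylprop-1-en-1-yl on a carbonyl carbon.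

Within the data shown here, the series holds no step between measured compounds that differ in one place, so this change has no direct precedent. Among the measured compounds shown here, the only guide is the narrow spread of the values, with compound 1 at 6780 nM and compound 3 at 6870 nM within the scatter of each other, and compound 2 at 8840 nM within the scatter of both. On that basis, no step beyond the scatter is expected in this assay in either direction. The estimated move is a 1.0-fold higher number from compound 3 to compound 4 (0.01 log units; within the scatter) and it remains an expectation only. For compound 4 the expected value is 7000 nM with an estimated range from 3500 nM to 14000 nM on this measure.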

Compound 4, half-maximal inhibitory concentration: 1210 nM
Compound 4: middle estimate off by 5.8-fold (0.76 log units), on the high side, and the stated range ends above it.
By their numbers in this assay, from the lowest: compound 4; then compounds 1, 3 and 2 (each within the scatter of the next).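

In this assay, within the data shown here, the group on the carbonyl carbon, whose other neighbour is the amide-type nitrogen, is the first place to show a step beyond the scatter: pent-1-en-1-yl in place of 2-methylprop-1-en-1-yl gives a 5.7-fold lower number from compound 3 to compound 4 (0.75 log units; beyond the scatter), with the rest of the molecule unchanged. By count the two groups are close, with 4 heavy atoms leaving and 5 entering, each with no ring, 1 double bond outside aromatic rings and 0 hydrogen-bond donors or acceptors, so an edit this small at this position is enough to move the number beyond the scatter. No measurement at hand bears on why the number moves.

This single pair cannot separate the extra carbon from the change from a branched to an unbranched chain, and a saturated pentyl chain, a hex-1-en-1-yl chain or a chain ending in a dimethylamino group would each test a different part of that question. From the compounds shown here alone, it also remains open whether pent-1-en-1-yl brings a similar step on the core of compound 1.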